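The source may hold more compounds than are shown below. What is called first, only, known or untested is meant among the compounds shown, and "the series" means these compounds.

Measured compounds:
compound 1 `O=C(CSc1nnc(-c2ccncc2)o1)N/N=C/c1ccc(Br)cc1`: 19100 nM
compound 2 `O=C(CSc1nnc(-c2ccncc2)o1)N/N=C/c1cc(Br)cc(Br)c1O`: 9010 nM
compound 3 `O=C(CSc1nnc(-c2ccncc2)o1)N/N=C/c1cccs1`: 23500 nM

In a functional assay on MCF7 cells (Homo sapiens) for cytotoxicity, read by MTT assay, with a stated time of 48 h (on this read-out lower numbers stand for stronger inhibition and higher numbers for weaker inhibition), compound 1 stands second highest of the three numbers; compound 3 sits within the scatter of it, while compound 2 gives a 2.1-fold lower number from compound 1 to compound 2 (0.33 log units; beyond the scatter). The unmeasured compound 4 `O=C(CSc1nnc(-c2ccncc2)o1)N/N=C/C=C/c1ccccc1` differs from compound 1 in one place: 2-phenylethenyl in place of 4-bromophenyl on a carbon with a double bond to nitrogen. Both measured steps alter the same carbon and therefore bear on this change: a 2.1-fold lower number from compound 1 to compound 2 (0.33 log units; beyond the scatter) and a 1.2-fold higher number from compound 1 to compound 3 (0.09 log units; within the scatter). Going by the values given here, neither exceeds a modest size, and no measured compound carries a 2-phenylethenyl group, so only a small shift, if any beyond the scatter, is expected in this assay. Compound 4 is therefore estimated at 18000 nM, in a range from 8000 nM to 45000 nM. The expected step is a 1.1-fold lower number from compound 1 to compound 4 (0.03 log units; within the scatter).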

Compound 4, half-maximal inhibitory concentration: 10800 nM
Compound 4: middle estimate off by 1.7-fold (0.22 log units), on the high side, and the stated range covers the measured number.
By their numbers in this assay, from the lowest: compounds 2, 4, 1 and 3 (each within the scatter of the next, the first and the last beyond it).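

At the carbon with a double bond to nitrogen in this assay, 2-phenylethenyl stays within the scatter of 4-bromophenyl, with a 1.8-fold lower number from compound 1 to compound 4 (0.25 log units; within the scatter), and of 3,5-dibromo-2-hydroxyphenyl, with a 1.2-fold higher number from compound 2 to compound 4 (0.08 log units; within the scatter), so a group without bromine matches both brominated groups here. It separates only from thiophen-2-yl, with a 2.2-fold lower number from compound 3 to compound 4 (0.34 log units; beyond the scatter). No measurement offered here accounts for these differences. The compounds shown leave open whether an amine or a carboxylic acid at this carbon, or a longer chain ending in phenyl, would move the number beyond the scatter of compound 2.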